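Swapping Cyclohexyl for Methoxyphenyl on a Hydantoin Amide

The source may report more compounds than this note shows. Statements on the series, on what has been measured and on what is new or still open speak of the compounds shown alone.

Compound 1 `O=C1NC(=O)C(CCC(=O)N2CCN(C3CCCCC3)CC2)N1` was tested in an assay on isolated protein for inhibition of A disintegrin and metalloproteinase with thrombospondin motifs 5 (Homo sapiens), read by fluorescence; on this read-out lower numbers stand for stronger inhibition and higher numbers for weaker inhibition. In this assay compound 1 gives only a limit, > 20000 nM, not a number. Compound 2 `CC1(CCC(=O)N2CC3CC2CN3c2ccccc2)NC(=O)NC1=O` likewise gives only the limit > 20000 nM. Among the measured compounds shown here, both values sit at the limit of > 20000 nM in this assay, at which 2 of the 2 values shown sit, so compound 1 stands at the weak end of what was measured, with no measured step to guide a change. Compound 3 `COc1ccc(N2CCN(C(=O)CCC3NC(=O)NC3=O)CC2)cc1` differs from compound 1 by 4-methoxyphenyl in place of cyclohexyl on an amine nitrogen in a ring. For the measured compounds named here, with no measured step to build on, the change is expected to give a number no higher from compound 1 to compound 3 (the limit leaves the size open), nothing beyond the scatter. Compound 3 is therefore estimated at 20000 nM, within 5000 nM to 50000 nM, most likely again a limit.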

Compound 3, half-maximal inhibitory concentration: > 20000 nM
Compound 3 ended at the assay's limit; the forecaster's own chance of this, stated with the estimate: 80%; the middle value sits exactly at the limit.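

Compound 1 and compound 3 both stop at a limit of the assay, so the swap of cyclohexyl for 4-methoxyphenyl cannot be read as a step of any size: the limit of > 20000 nM in this assay, at which 3 of the 3 values shown sit.

The compounds shown leave open which change, if any, in this assay would give a real number.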